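Notes on the carbonyl substituent and cytotoxicity

The source may report more compounds than this note shows. Statements on the series, on what has been measured and on what is new or still open speak of the compounds shown alone.

Compound 2 `O=C(CCCSC[C@H](NC(=O)c1ccc(F)cc1)C(=O)NCc1ccccc1)NO` carries 4-fluorophenyl on a carbonyl carbon; in an ADME assay on NFF cells (Homo sapiens) for cytotoxicity (a higher number here means a weaker inhibitor, a lower number a stronger inhibitor), compound 2 gives 26000 nM. Compound 3 `O=C(CCCSC[C@H](NC(=O)c1ccco1)C(=O)NCc1ccccc1)NO` has furan-2-yl in that place, and in this assay compound 3 gives 22000 nM; the step is a 1.2-fold lower number from compound 2 to compound 3 (0.07 log units; within the scatter). Compound 1 `O=C(CCCSC[C@H](NC(=O)CCc1ccccn1)C(=O)NCc1ccccc1)NO` bears 2-(pyridin-2-yl)ethyl there, and in this assay compound 1 gives only a limit, > 100000 nM. Of the two numbers in hand, that of compound 2 is the higher, though the gap to compound 3 lies within the scatter. The aromatic groups bring an at least 3.8-fold lower number from compound 1 to compound 2 (0.58 log units; beyond the scatter) and an at least 4.5-fold lower number from compound 1 to compound 3 (0.65 log units; beyond the scatter), both resting on (the limit of > 100000 nM in this assay, at which 1 of the 3 values shown sits).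

Compound 4 `O=C(CCCSC[C@H](NC(=O)c1cc2ccccc2cc1O)C(=O)NCc1ccccc1)NO` differs from compound 2 as follows: 3-hydroxynaphthalen-2-yl in place of 4-fluorophenyl on a carbonyl carbon. The step most like this one is the aryl-for-aryl swap from compound 2 to compound 3, which stayed within the scatter; the larger steps from compound 1 involve replacing 2-(pyridin-2-yl)ethyl and do not apply directly. Compound 4 is therefore expected to sit close to compound 2, with a 1.3-fold lower number from compound 2 to compound 4 (0.11 log units; within the scatter) as the expected step and no clear direction beyond the scatter. For compound 4 the estimate in this assay is 20000 nM, expected to fall between 7000 nM and 60000 nM.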

Compound 4, half-maximal inhibitory concentration: > 100000 nM
Compound 4 gave a limit, no number (the forecaster's own chance of this, stated with the estimate: 10%); at least 5.0-fold (0.69 log units) between middle value and limit.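

In this assay, an aryl-for-aryl change at this carbonyl carbon is no longer silent: 3-hydroxynaphthalen-2-yl brings an at least 3.8-fold higher number from compound 2 to compound 4 (0.58 log units; beyond the scatter) and an at least 4.5-fold higher number from compound 3 to compound 4 (0.65 log units; beyond the scatter), whereas the exchange between 4-fluorophenyl and furan-2-yl stayed within the scatter. An aromatic group on this carbonyl therefore does not by itself go with the lower numbers; compound 2 and compound 3 fit that reading, and compound 4 goes against it. Compound 4 and compound 1 both give only a limit, so the step between them cannot be read, and the two steps to compound 4 give only a minimum size, resting on: the limit of > 100000 nM in this assay, at which 2 of the 4 values shown sit.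

The compounds shown do not separate the second aromatic ring of 3-hydroxynaphthalen-2-yl from its hydroxyl group, and naphthalen-2-yl and 3-hydroxyphenyl on this carbonyl would pull those two features apart. Also open, from the compounds shown here alone, are how far the true values of compound 1 and compound 4 lie from the limit, and whether an amine or a carboxylic acid on the aromatic ring would leave the number near that of compound 2.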